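Working notes: lipophilicity across three ethers and one analogue

The source may report more compounds than this note shows. Statements on the series, on what has been measured and on what is new or still open speak of the compounds shown alone.

Measured compounds in a physicochemical assay for lipophilicity, read by HPLC, in phosphate buffer, measured as chromatographic lipophilicity, at pH 7.4; a higher number here means a more lipophilic compound, a lower number a more polar compound:
compound 1 `CCC(Oc1cc(C)nc2ccc(OC)cc12)C(=O)Nc1cc(C)cc(C)c1`: 6.28
compound 2 `COc1ccc2nc(C)cc(OCc3ccc4ccccc4n3)c2c1`: 5.48
compound 3 `COc1ccc2nc(C)cc(OCC(=O)Nc3cc(C)ccc3OC)c2c1`: 5.65

Compound 3 holds the second highest of the three numbers. Compound 2 lies nearest to it, and the gap between compound 3 and compound 2 is within the usual scatter, so no order between them is claimed. Compound 1 is furthest away, sitting higher than compound 3 by a gap beyond the scatter. Among the measured compounds shown here, no two of the measured compounds differ in one place only, so no single measured step is available from them.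

Compound 4 `COc1ccc2nc(C)cc(OCC(=O)NC3CONC3=O)c2c1` has not yet been measured. It differs from compound 3 in one place: a group of 6 heavy atoms (3 carbon, 1 nitrogen, 2 oxygen; one five-membered non-aromatic ring with 2 hetero atoms) in place of a group of 9 heavy atoms (8 carbon, 1 oxygen; one six-membered aromatic ring of carbon only), on an amide-type nitrogen. Nothing measured in this set isolates such a change, so the expectation rests on the change itself and on the value of compound 3.

Compound 4 is expected to fall well below compound 3, with a step of a number 2.65 log units lower from compound 3 to compound 4 (beyond the scatter) lying clearly beyond the scatter. The estimate for compound 4 in this assay is 3, with a range from 2.2 to 3.8.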

Compound 4, distribution coefficient: 0.79
The estimate for compound 4 lay 2.21 log units above the measured number, and the stated range ends above it.
By their numbers in this assay, from the lowest: compound 4; then compounds 2 and 3 (each within the scatter of the next); then compound 1.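

Among the compounds shown here, on the amide-type nitrogen, putting the five-membered non-aromatic ring with 2 hetero atoms in place of 2-methoxy-5-methylphenyl gives the first single-place step in this set. In this assay this change gives a number 4.86 log units lower from compound 3 to compound 4 (beyond the scatter), so the group at this one position can by itself move the number far beyond the scatter while the rest of the molecule stays the same. No measurement at hand accounts for the size of this step.

The step changes ring size, aromatic character, hetero atoms and hydrogen-bond donor count together, and these cannot be separated from this single pair. On these data alone, whether a plain phenyl, a cyclopentyl ring or an ethyl chain on the same nitrogen would give a number nearer compound 3 or nearer compound 4 remains open.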